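Chloro for methyl on the core: cytotoxicity outlook

The source may hold more compounds than are shown below. What is called first, only, known or untested is meant among the compounds shown, and "the series" means these compounds.

Compound 3 `Cc1ccc2[nH]c(=O)c(CN(Cc3ccc(N(C)C)cc3)Cc3ccc(C(C)(C)C)cc3)cc2c1` is one of three close relatives tested in a toxicity assay on MDCK cells (Canis lupus familiaris) for cytotoxicity, read by crystal violet staining, with a stated time of 48 h; on this read-out lower numbers stand for higher toxicity in this test and higher numbers for lower toxicity in this test. In this assay compound 3 gives only a limit, > 5000 nM. Compound 2 `Cc1ccc2[nH]c(=O)c(CN(Cc3ccc(OC(C)C)cc3)Cc3ccc(C(C)(C)C)cc3)cc2c1` also reaches only a limit in this assay, > 5000 nM. Compound 1 `Cc1ccc2[nH]c(=O)c(CN(Cc3ccc(F)cc3)Cc3ccc(C(C)(C)C)cc3)cc2c1` gives a limit too, > 27000 nM. The steps among these three, a step that the two limits leave unreadable from compound 1 to compound 2, a step that the two limits leave unreadable from compound 1 to compound 3 and a step that the two limits leave unreadable from compound 2 to compound 3, cannot be sized, since every value is a limit: the limit of > 27000 nM in this assay, at which 1 of the 3 values shown sits, and the limit of > 5000 nM in this assay, at which 2 of the 3 values shown sit, are all the evidence there is.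

Compound 4 `CN(C)c1ccc(CN(Cc2ccc(C(C)(C)C)cc2)Cc2cc3cc(Cl)ccc3[nH]c2=O)cc1` differs from compound 3 by chloro in place of methyl on an aromatic carbon. Going by the values given here, none of the measured steps touches this part of the shared core, and none of them has a readable size, so no direction can be read from them. The expectation is therefore no step beyond the scatter, a step that the limit leaves unreadable from compound 3 to compound 4, and compound 4 is estimated at 20000 nM, ranging from 5000 nM to 80000 nM, most probably again reported only as a limit.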

Compound 4, half-maximal cytotoxic concentration: > 10000 nM
Compound 4 gave a limit, no number (the forecaster's own chance of this, stated with the estimate: 80%); the middle value lies beyond the limit too.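

Compound 3 and compound 4 both give only limits in this assay and no numbers, and the step between them, chloro in place of methyl on an aromatic carbon, cannot be read. The four compounds shown leave open the concentration at which any of them harms the cells in this assay and whether chloro and methyl differ at all.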